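The source may report more compounds than this note shows. Statements on the series, on what has been measured and on what is new or still open speak of the compounds shown alone.

Working notes on the series. Compound 3 `O=c1cc(-c2ccc(-c3ccccc3)cc2)oc2cc(OCCCCCCCCN3CCCC3)ccc12` stands highest of the three measured compounds: in an ADME assay on HepG2 cells (Homo sapiens) for cytotoxicity, read by MTT assay, with a stated time of 48 h, tested at 10 uM (a lower number here means a weaker effect, a higher number a stronger effect of the compound at the concentration tested), compound 3 gives 71.9%. Compound 1 `O=c1cc(-c2cccc(O)c2)oc2cc(OCCCCCCCCN3CCCC3)ccc12` gives 43.9%, and compound 2 `O=c1cc(-c2ccccc2)oc2cc(OCCCCCCCCN3CCCC3)ccc12` gives 8.97%. Compound 4 `O=c1cc(-c2ccccc2O)oc2cc(OCCCCCCCCN3CCCC3)ccc12` is not yet measured; it differs from compound 3 in one place: 2-hydroxyphenyl in place of 4-phenylphenyl on an aromatic carbon. Within the data shown here, two measured steps bear on this change. The step of a number 28 percentage points higher from compound 1 to compound 3 (beyond the scatter) runs the opposite way to part of it, and the step of a number 62.9 percentage points higher from compound 2 to compound 3 (beyond the scatter) covers the added phenyl alone; the step of a number 34.9 percentage points lower from compound 1 to compound 2 (beyond the scatter) concerns the hydroxy alone. Compound 4 is therefore expected to fall in this assay, with an estimated step of a number 31.9 percentage points lower from compound 3 to compound 4 (beyond the scatter). Compound 4 is estimated at 40%, with a range from 15% to 65%.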

Compound 4, a percentage reported as inhibition, at one concentration (the size of the read-out at that concentration, not a potency): 60.6%
The estimate for compound 4 lay 20.6 percentage points below the measured number, and the stated range covers the measured number.
By their numbers in this assay, from the lowest: compound 2; then compound 1; then compound 4; then compound 3.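

In this assay, the place of the hydroxy on the phenyl counts: 2-hydroxyphenyl in place of 3-hydroxyphenyl gives a number 16.7 percentage points higher from compound 1 to compound 4 (beyond the scatter). Hydroxy in place of hydrogen on the 2-position of the phenyl gives a number 51.6 percentage points higher from compound 2 to compound 4 (beyond the scatter). A single hydroxylated ring still stays short of 4-phenylphenyl, with a number 11.3 percentage points lower from compound 3 to compound 4 (beyond the scatter). Nothing available explains why the place of the hydroxy matters. Open, from the compounds shown here alone, is how 4-hydroxyphenyl would compare, and whether a methoxy or an amine on the 2-position of the phenyl would behave as the hydroxy does.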